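Compound 3 to compound 4: methyl replaced by diethylamino

The source may hold more compounds than are shown below. What is called first, only, known or untested is meant among the compounds shown, and "the series" means these compounds.

Values in a functional assay on A549 cells (Homo sapiens) for cytotoxicity, read by CCK-8 assay; on this read-out higher numbers stand for weaker inhibition and lower numbers for stronger inhibition
compound 1 `O=C(Nc1ccc(O)cc1)c1ncc(-c2ccc(F)cc2)o1` gives > 30000 nM
compound 2 `O=C(Nc1cccc(O)c1)c1ncc(-c2ccccc2)o1` gives > 30000 nM
compound 3 `Cc1ccc(NC(=O)c2ncc(-c3ccccc3)o2)cc1` gives > 30000 nM

Compound 3 stands at > 30000 nM as a limit and not a number. The whole set sits at the limit of > 30000 nM in this assay, at which 3 of the 3 values shown sit, with no number to read. Compound 4 `CCN(CC)c1ccc(NC(=O)c2ncc(-c3ccccc3)o2)cc1` carries diethylamino in place of methyl on an aromatic carbon, and the counted change is diethylamino in place of methyl on an aromatic carbon as computed. Within the data shown here, the only measured step bearing on this is a step that the two limits leave unreadable from compound 2 to compound 3 and it gives no size to carry over. Compound 4 is therefore expected close to that limit, with any move toward stronger inhibition small. The expected step is an at least 1.5-fold lower number from compound 3 to compound 4 (0.17 log units; that floor lies within the scatter) in this assay on present data. For compound 4 the estimate is 20000 nM with an expected range of 5000 nM to 30000 nM for now.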

Compound 4, half-maximal inhibitory concentration: > 30000 nM
Compound 4: no number, only a limit (the forecaster's own chance of this, stated with the estimate: 60%); middle value at least 1.5-fold (0.17 log units) away from the limit.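

No step can be read from compound 3 to compound 4, as both values are limits and not numbers: the limit of > 30000 nM in this assay, at which 4 of the 4 values shown sit.

The compounds shown leave open which change to the shared core, if any, would give a readable value.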